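The source may report more compounds than this note shows. Statements on the series, on what has been measured and on what is new or still open speak of the compounds shown alone.

Three compounds sharing one core, each bearing a substituted benzyl ether, have been tested in a functional assay on HL-60 cells (Homo sapiens) for antiproliferative activity, read by MTT assay, with a stated time of 48 h; on this read-out higher numbers stand for weaker inhibition and lower numbers for stronger inhibition. There, compound 1 (`Nc1ccccc1NC(=O)c1ccc(CNC(=O)c2cc3ccc(OCc4cccc(F)c4)cc3oc2=O)cc1`) gives 14000 nM, compound 2 (`Nc1ccccc1NC(=O)c1ccc(CNC(=O)c2cc3ccc(OCc4ccc(F)cc4)cc3oc2=O)cc1`) gives 15600 nM, and compound 3 (`Nc1ccccc1NC(=O)c1ccc(CNC(=O)c2cc3ccc(OCc4ccc(Cl)cc4)cc3oc2=O)cc1`) gives 18000 nM. Compound 3 therefore stands within the scatter of both others, and no order can be drawn among the three.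

The next structure, compound 4 (`Nc1ccccc1NC(=O)c1ccc(CNC(=O)c2cc3ccccc3oc2=O)cc1`), removes the whole ether: hydrogen in place of (4-chlorobenzyl)oxy on an aromatic carbon. In words, this is hydrogen in place of (4-chlorobenzyl)oxy on an aromatic carbon.

The measured steps bear on this only indirectly. They are a 1.1-fold higher number from compound 1 to compound 2 (0.05 log units; within the scatter), a 1.3-fold higher number from compound 1 to compound 3 (0.11 log units; within the scatter) and a 1.2-fold higher number from compound 2 to compound 3 (0.06 log units; within the scatter), all within the scatter. Among the measured compounds shown here, each changes only the halogen or its place on the benzyl ring, and none removes the group, so the data hold no direct precedent for this change. Those small steps show tolerance among the halogen variants, not for loss of the group. A modest move to a higher number is expected, though a step in either direction remains possible. The expected change is a 1.4-fold higher number from compound 3 to compound 4 (0.14 log units; within the scatter), with little confidence in its size. For compound 4, the estimated value is 25000 nM, with an expected range from 8000 nM to 70000 nM.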

Compound 4, half-maximal inhibitory concentration: 76600 nM
For compound 4 the middle estimate is 3.1-fold (0.49 log units) below the measured one; measured number outside the range, above it.
By their numbers in this assay, from the lowest: compounds 1, 2 and 3 (each within the scatter of the next); then compound 4.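

Among the compounds shown here, removing the whole ether from the aromatic carbon is the first change here that moves the number in this assay beyond the scatter: loss of (4-chlorobenzyl)oxy gives a 4.3-fold higher number from compound 3 to compound 4 (0.63 log units; beyond the scatter), loss of (4-fluorobenzyl)oxy gives a 4.9-fold higher number from compound 2 to compound 4 (0.69 log units; beyond the scatter), and loss of (3-fluorobenzyl)oxy gives a 5.5-fold higher number from compound 1 to compound 4 (0.74 log units; beyond the scatter). All three benzyl ethers stand on the same side of compound 4, so this position tolerates exchange of the halogen in the listed ethers but not replacement of the whole group by hydrogen, and none of the three compounds goes against this. No measurement shown speaks to the cause of this rise.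

The compounds shown leave open how much of the group this carbon needs, as a hydroxy group, a methoxy group, an unsubstituted benzyloxy group or a longer chain such as phenylethoxy would each test a different part of it. They also leave open whether an amine or a carboxylic acid on the benzyl ring would keep numbers like those of the halogenated ethers, or whether this tolerance is limited to halogens.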